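The compounds below may be only part of what the source reports. "The series", "measured", "known", "first", "only" and "open" are said of these compounds alone.

In a physicochemical assay for solubility, in phosphate buffer, measured as kinetic solubility, at pH 7.4 (on this read-out lower numbers stand for lower solubility and higher numbers for higher solubility), three related compounds have been measured. Compound 1 `Cc1ccc(C)c(-c2nc(CN3CCC(C(=O)NCCCN4C[C@H](C)C[C@H](C)C4)CC3)c(C)o2)c1` gives 56.1 ug/mL. Compound 2 `Cc1oc(-c2ccccc2Cl)nc1CN1CCC(C(=O)NCCCN2C[C@H](C)C[C@H](C)C2)CC1` reads > 72 ug/mL, which is a limit and not a number. Compound 3 `Cc1ccccc1-c1nc(CN2CCC(C(=O)NCCCN3CCC(C)CC3)CC2)c(C)o1` reads > 67 ug/mL, which is also a limit, so its exact place on the scale is not known.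

Compound 4 `Cc1ccccc1-c1nc(CN2CCC(C(=O)NCCCCN3C[C@H](C)C[C@H](C)C3)CC2)c(C)o1` differs from compound 3 at one place: (3,5-dimethylpiperidin-1-yl)methyl in place of 4-methylpiperidin-1-yl on a saturated chain carbon, three bonds along the chain from an amide-type nitrogen. In words, (3,5-dimethylpiperidin-1-yl)methyl stands in place of 4-methylpiperidin-1-yl on a saturated chain carbon, three bonds along the chain from an amide-type nitrogen.

Going by the values given here, only one measured step exists, and it offers little direct guidance. The step of an at least 1.2-fold higher number from compound 1 to compound 2 (0.10 log units; that floor lies within the scatter) puts 2-chlorophenyl in place of 2,5-dimethylphenyl, a different change from the one at hand, and it stays within the scatter. More useful is that compound 1 carries a 3,5-dimethylpiperidin-1-yl group and gives 56.1 ug/mL, a real number. Compound 2 carries that group too, yet it reaches only a limit, so the group alone sets no clear level.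

The estimated step, an at least 1.1-fold lower number from compound 3 to compound 4 (0.04 log units; that floor lies within the scatter), is expected to stay within the scatter. For compound 4 the estimate is 60 ug/mL, with an expected range from 35 ug/mL to 85 ug/mL.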

Compound 4, solubility: > 71 ug/mL
Compound 4: only a limit was reported; the forecaster's own chance of this, stated with the estimate: 40%; middle value at least 1.1-fold (0.07 log units) away from the limit.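

Compound 3 and compound 4 both stand only as limits in this assay, and the step between them cannot be read. The compounds shown leave open whether putting (3,5-dimethylpiperidin-1-yl)methyl in place of 4-methylpiperidin-1-yl moves this read-out at all, and if it does, in which direction and how far.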